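From compound 2 to compound 3: amide nitrogen substituent

This account rests on a few compounds, and the source may have more. Where it says the series, first, only, none or still open, it means among the compounds named here.

In an ADME assay on S9 fraction from liver (Rattus norvegicus) for metabolic stability, with a stated time of 60 min (on this read-out higher numbers stand for a more stable compound and lower numbers for a less stable compound), compound 1 `CO[C@H]1CC[C@H](CN2C(=O)CNc3ncc(-c4ccc(-c5nc[nH]n5)nc4C)nc32)CC1` gives 100%. Compound 2 `Cc1nc(-c2nc[nH]n2)ccc1-c1cnc2c(n1)N([C@H]1CC[C@@H](O)CC1)C(=O)CN2` gives 100%, level with compound 1 at the digits reported. Compound 3 `Cc1nc(-c2nc[nH]n2)ccc1-c1cnc2c(n1)N(CC1CCOCC1)C(=O)CN2`, not yet measured, differs from compound 2 in one place: (oxan-4-yl)methyl in place of 4-hydroxycyclohexyl on an amide-type nitrogen in a ring. In words, (oxan-4-yl)methyl stands in place of 4-hydroxycyclohexyl on an amide-type nitrogen in a ring. For the measured compounds named here, only one measured step bears on this change, and it involves the same nitrogen. That step is no change at the digits printed from compound 1 to compound 2 (within the scatter), with 4-hydroxycyclohexyl in place of (4-methoxycyclohexyl)methyl. With only no change at the digits printed from compound 1 to compound 2 (within the scatter) to go on, no step beyond the scatter is expected in this assay, though a single step is thin evidence. The expected step is a number 5 percentage points lower from compound 2 to compound 3 (within the scatter). For compound 3 the estimated value is 95%, with an expected range of 82% to 100%.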

Compound 3, percent of the compound remaining: 100%
Beside the measured number, compound 3's estimate is 5 percentage points below it; the measured number falls inside the stated range.
By their numbers in this assay, from the lowest: compounds 1, 2 and 3 (each within the scatter of the next).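

Notes on the amide-type nitrogen in a ring: in this assay, replacing 4-hydroxycyclohexyl with (oxan-4-yl)methyl gives no change at the digits printed from compound 2 to compound 3 (within the scatter), so moving the oxygen into the ring, losing the hydrogen-bond donor and losing the defined stereocentres together leave this read-out unmoved. Replacing 4-methoxycyclohexyl with oxan-4-yl on the saturated chain carbon bound to that nitrogen gives no change at the digits printed from compound 1 to compound 3 (within the scatter), so a second change at this site also leaves the printed value as it was. No available measurement accounts for this flat result.

All the groups shown at this site are oxygen-bearing six-membered rings, so whether an amine such as piperidin-4-yl or a carboxylic acid would hold the same value in this assay stays open. A plain alkyl chain on this nitrogen is equally untested among these compounds.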